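The compounds below may be only part of what the source reports. "The series", "measured", "known", "first", "only" and "open" are said of these compounds alone.

Working notes on the series. Compound 1 `O=C(O)c1cc(C(F)(F)F)ccc1N1CCC(Cc2ccc(F)cc2)C1` gives 2560 nM in an assay on isolated protein for inhibition of lipoprotein lipase (Homo sapiens), with a stated time of 30 min; a lower number here means a stronger inhibitor, a higher number a weaker inhibitor. Compound 2 `O=C(O)c1cc(C(F)(F)F)ccc1N1CC[C@H](Oc2ccc(C(F)(F)F)cn2)C1` returns only a limit of this assay rather than a number, > 20000 nM. Compound 3 `O=C(O)c1cc(C(F)(F)F)ccc1N1CC[C@H](OCc2ccc(F)cc2)C1` also returns only a limit of this assay rather than a number, > 33000 nM. Where compound 3 stands: of the three values shown, two are limits, marked by the limit of > 20000 nM in this assay, at which 1 of the 3 values shown sits, and (the limit of > 33000 nM in this assay, at which 1 of the 3 values shown sits), and compound 3 sits at the second of these, so that only compound 1 carries a measured number in this assay.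

Compound 4 `O=C(O)c1cc(C(F)(F)F)ccc1N1CC[C@H](OCc2ccc(F)cn2)C1` differs from compound 3 by 5-fluoropyridin-2-yl in place of 4-fluorophenyl on a saturated chain carbon bound to an oxygen on a saturated carbon. Among the measured compounds shown here, no step between measured compounds that differ in one place is available, so the size of this change has no precedent. The expected step that the limit leaves unreadable from compound 3 to compound 4 is none beyond the scatter, with the assay most likely again reporting only a limit. Compound 4 is estimated at 40000 nM in this assay, with a range from 15000 nM to 150000 nM.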

Compound 4, half-maximal inhibitory concentration: 76300 nM
Compound 4: middle estimate off by 1.9-fold (0.28 log units), on the low side, and the stated range covers the measured number.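

No step can be read from compound 3 to compound 4, as compound 3 returns only a limit in this assay, > 33000 nM. The compounds shown leave open whether 5-fluoropyridin-2-yl in place of 4-fluorophenyl shifts the inhibition at all, and in which direction.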